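Methylating one catechol hydroxyl in the acylhydrazone series

The compounds below may be only part of what the source reports. "The series", "measured", "known", "first", "only" and "open" are said of these compounds alone.

Measured so far:
compound 1 `COc1ccc(OC)c(/C=N/NC(=O)Nc2ccc(Oc3ccnc(-c4nncn4CCN(C)C)c3)c(F)c2)c1`: 1510 nM
compound 2 `CN(C)CCn1cnnc1-c1cc(Oc2ccc(NC(=O)N/N=C/c3ccc(O)c(O)c3)cc2F)ccn1`: 3240 nM

In a functional assay on MKN-45 cells (Homo sapiens) for cytotoxicity, read by MTT assay, with a stated time of 72 h (on this read-out lower numbers stand for stronger inhibition and higher numbers for weaker inhibition), compound 1 gives 1510 nM and compound 2 gives 3240 nM. Going by the values given here, compound 2 stands highest of the two numbers; its nearest neighbour is compound 1, and the single measured step, a 2.1-fold higher number from compound 1 to compound 2 (0.33 log units; beyond the scatter), came with 3,4-dihydroxyphenyl in place of 2,5-dimethoxyphenyl on a carbon with a double bond to nitrogen.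

Compound 3 `COc1cc(/C=N/NC(=O)Nc2ccc(Oc3ccnc(-c4nncn4CCN(C)C)c3)c(F)c2)ccc1O` differs from compound 2 by methyl in place of hydrogen on an oxygen on an aromatic ring, which cut one bond further out reads hydroxy to methoxy, 3,4-dihydroxyphenyl to 4-hydroxy-3-methoxyphenyl. The step from compound 1 to compound 2 bears on this only in part: it exchanged both hydroxy groups for methoxy and also moved them on the ring. Converting one hydroxy to methoxy is expected to return part of the way toward the number of compound 1, so a modest lowering, a 1.5-fold lower number from compound 2 to compound 3 (0.17 log units; within the scatter), is expected. Compound 3 is therefore estimated at 2200 nM, within 1000 nM to 4800 nM.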

Compound 3, half-maximal inhibitory concentration: 3780 nM
Estimate against measurement, compound 3: 1.7-fold (0.24 log units) below; the measured number falls inside the stated range.
By their numbers in this assay, from the lowest: compound 1; then compounds 2 and 3 (each within the scatter of the next).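

In this assay, methylating one hydroxy of the 3,4-dihydroxyphenyl group gives a 1.2-fold higher number from compound 2 to compound 3 (0.07 log units; within the scatter), so at this oxygen on an aromatic ring the read-out does not separate hydroxy from methoxy. The other comparison gives a 2.5-fold higher number from compound 1 to compound 3 (0.40 log units; beyond the scatter): replacing a single hydroxy with methoxy does not close the gap to the 2,5-dimethoxyphenyl compound, and that gap remains with the full exchange of the ring substituents. No measurement at hand accounts for either result.

Whether the gap to compound 1 follows from the number of methoxy groups or from their places on the ring stays open, as the compounds shown change both together. Also open, as far as these compounds go, is how an ethoxy group or an amine would read in place of this methoxy.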